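Aryl ketone swap in the chalcone amide series

A few compounds are considered here, and "the series" means these few. Any claim that something is new, unique, unknown or untested is made for them only; others in the source may bear on it.

Compound 1 `COC(=O)c1cc(-c2cccc(NC(=O)c3ccc(/C=C/C(=O)c4cccnc4)cc3)c2)on1` has no result in an ADME assay on Vero cells (Chlorocebus sabaeus) for cytotoxicity, read by MTT assay, with a stated time of 72 h; on this read-out lower numbers stand for higher toxicity in this test and higher numbers for lower toxicity in this test: its entry reads "not determined" (no result reported), so it stands on no number among those shown. Two companions frame the series. Compound 2 `CC(C)Cc1ccc(C(=O)/C=C/c2ccc(C(=O)O)cc2)cc1` gives < 10 ug/mL in this assay, which is the limit of < 10 ug/mL in this assay, at which 1 of the 3 values shown sits. Compound 3 `COC(=O)c1cc(-c2cccc(NC(=O)c3ccc(/C=C/C(=O)c4cccc(C(F)(F)F)c4)cc3)c2)on1` is built on the same core as compound 1. In this assay compound 3 gives > 20 ug/mL, which is the limit of > 20 ug/mL in this assay, at which 1 of the 3 values shown sits. The step to compound 4 `CCOc1ccc(C(=O)/C=C/c2ccc(C(=O)Nc3cccc(-c4cc(C(=O)OC)no4)c3)cc2)cc1` is 4-ethoxyphenyl in place of pyridin-3-yl on a carbonyl carbon. Going by the values given here, no measured pair shows a step of this kind, so its size is unknown; with compound 1 unmeasured, the expectation rests on compound 3 at > 20 ug/mL, with no shift beyond the scatter and a result likely reported again only as a limit. Compound 4 is expected near 25 ug/mL, between 10 ug/mL and 60 ug/mL.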

Compound 4, half-maximal cytotoxic concentration: > 40 ug/mL
Compound 4: only a limit was reported (the forecaster's own chance of this, stated with the estimate: 70%); at least 1.6-fold (0.20 log units) between middle value and limit.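

Going by these compounds alone, compound 3 and compound 4 are each reported only as a limit in this assay, so no step between them can be read. The compounds shown leave open how far 4-ethoxyphenyl and 3-(trifluoromethyl)phenyl differ, and where compound 1 stands.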